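The source may hold more compounds than are shown below. What is called first, only, known or untested is meant among the compounds shown, and "the series" means these compounds.

Measured so far, in a physicochemical assay, read by spectrophotometry, with a stated time of 30 min; on this read-out higher numbers stand for weaker inhibition and lower numbers for stronger inhibition:

compound 1 `O=[N+]([O-])c1cccc(Cn2cc(COc3ccccc3)nn2)c1` gives 25.3 ug/mL
compound 2 `Clc1cccc(Cn2cc(COc3ccccc3)nn2)c1` gives 27.3 ug/mL
compound 3 `O=[N+]([O-])c1ccc(Cn2cc(COc3cccc([N+](=O)[O-])c3)nn2)cc1` gives 17.1 ug/mL

Compound 1 and compound 2 differ in one place: chloro in place of nitro on an aromatic carbon. The step that this change made is a 1.1-fold higher number from compound 1 to compound 2 (0.03 log units; within the scatter), so the two numbers do not separate in this assay.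

Compound 3 carries the same nitro group as compound 1 on the shared part of the structure, but the two differ in more than one place, and the difference between the two cores is not broken down here. In this assay compound 3 gives the lowest of the three numbers, yet its gaps to compound 1 and to compound 2 are both within the scatter, so no order among the three can be read.

Compound 4 `O=[N+]([O-])c1cccc(OCc2cn(Cc3ccc(Cl)cc3)nn2)c1` has not been measured. It stands to compound 3 as compound 2 stands to compound 1: chloro in place of nitro on an aromatic carbon. This is the same kind of change as that from compound 1 to compound 2, though not the same: there the chloro sits meta to a large group, here para to a large group. Within the data shown here, only one instance of this change has been measured, and it sits within the scatter.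

The expectation for compound 4 therefore rests on that one step: with the step from compound 1 to compound 2 being a 1.1-fold higher number from compound 1 to compound 2 (0.03 log units; within the scatter), the expected step from compound 3 to compound 4 is a 1.1-fold higher number from compound 3 to compound 4 (0.03 log units; within the scatter). In this assay compound 4 is estimated at 18.5 ug/mL, with a likely range from 10 ug/mL to 35 ug/mL.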

Compound 4, half-maximal inhibitory concentration: 37.3 ug/mL
Compound 4: middle estimate off by 2.0-fold (0.30 log units), on the low side; measured number outside the range, above it.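

In this assay, among these compounds, chloro in place of nitro, para to a large group, gives a 2.2-fold higher number from compound 3 to compound 4 (0.34 log units; beyond the scatter) and this modest step lies beyond the scatter, whereas the only other instance of the change, on the other core, gives a 1.1-fold higher number from compound 1 to compound 2 (0.03 log units; within the scatter) and stays within the scatter. The size of the step therefore did not carry over reliably from one core to the other, although both steps run towards a higher number, which stands for weaker inhibition; with only two instances, this does not show whether the core, the place of the change or ordinary scatter accounts for the contrast, and it gives no general rule for the series. Nothing on hand gives a reason for the contrast between the two steps.

The compounds shown leave open how groups other than nitro and chloro, such as an amine, a carboxylic acid or a nitrile, would behave at the place of this change on either core. They also leave open whether the larger step on the core of compound 4 would persist if its remaining nitro group gave way to chloro or to an amine.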